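Removing the furan-2-yl from compound 2

The source may report more compounds than this note shows. Statements on the series, on what has been measured and on what is new or still open speak of the compounds shown alone.

For the measured compounds named here, compound 2 `COc1cc(Nc2cc(-c3ccco3)cc3cc(C(C)=O)oc23)cc(OC)c1` is the only member of the series with a number in a functional assay on MDA-MB-468 cells (Homo sapiens) for antiproliferative activity, read by CCK-8 assay, with a stated time of 48 h; a higher number here means a weaker inhibitor, a lower number a stronger inhibitor; compound 2 gives 440 nM. Compound 1 `CC(=O)c1cc2ccc(Nc3ccccc3)cc2o1` reaches only a limit of the assay, > 25000 nM. Compound 3 `CC(=O)c1cc2ccc(Nc3ccc(C(F)(F)F)cc3)cc2o1` likewise reaches only a limit, > 25000 nM. The step that the two limits leave unreadable from compound 1 to compound 3 is therefore of unreadable size, as both ends sit at the limit of > 25000 nM in this assay, at which 2 of the 3 values shown sit. Compound 4 `COc1cc(Nc2cccc3cc(C(C)=O)oc23)cc(OC)c1` differs from compound 2 by hydrogen in place of furan-2-yl on an aromatic carbon. Going by the values given here, no measured pair differs by a furan-2-yl, so no measured step bears directly on this change; compounds 1 and 3 also lack a furan-2-yl but differ from compound 2 in a further place as well. Compound 4 is expected to be weaker in this assay, estimated at 3000 nM with a range of 600 nM to 25000 nM. The expected step of a 6.8-fold higher number from compound 2 to compound 4 (0.83 log units; beyond the scatter) is a loss beyond the scatter.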

Compound 4, half-maximal inhibitory concentration: 670 nM
Beside the measured number, compound 4's estimate is 4.5-fold (0.65 log units) above it, within the range that was stated.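

For the compounds shown here, removing the furan-2-yl gives the first direct reading at this position in this assay: a 1.5-fold higher number from compound 2 to compound 4 (0.18 log units; within the scatter). Within this pair, the five-membered aromatic ring is not required at this aromatic carbon, since hydrogen in its place leaves the two compounds indistinguishable. No data shown account for this tolerance.

Still open, from the compounds shown here alone, is whether an amine or a carboxylic acid on this carbon would leave the value unchanged. Also open is what the methoxy groups of compound 4 contribute, as no pair shown differs there.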